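Chloro substitution on two naphthalene-derived ester cores

This account rests on a few compounds, and the source may have more. Where it says the series, first, only, none or still open, it means among the compounds named here.

The series rests on two cores. Compound 1, `COc1c(OC)c(OC(=O)C(C)C)c2ccccc2c1OC(=O)C(C)C`, carries two methoxy groups and two isobutyrate esters; in a physicochemical assay for lipophilicity (on this read-out higher numbers stand for higher lipophilicity and lower numbers for lower lipophilicity), compound 1 gives 4.61. Compound 3, `COc1c(OC)c(OC(=O)C(C)C)c2cc(Cl)ccc2c1OC(=O)C(C)C`, differs from compound 1 only by chloro in place of hydrogen on an aromatic carbon, and in this assay compound 3 gives 5.4. Among the compounds with values here, the step of a number 0.79 log units higher from compound 1 to compound 3 (beyond the scatter) is the only measured step of its kind so far. Compound 2, `O=C(Oc1c(Oc2ccccc2)c(Oc2ccccc2)c(OC(=O)c2ccccc2)c2ccccc12)c1ccccc1`, carries two phenoxy groups and two benzoate esters; the difference between the two cores is not broken down here. In this assay compound 2 gives 7.9, the highest of the three values, beyond the scatter from both compound 3 and compound 1.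

Compound 4, `O=C(Oc1c(Oc2ccccc2)c(Oc2ccccc2)c(OC(=O)c2ccccc2)c2cc(Cl)ccc12)c1ccccc1`, stands to compound 2 as compound 3 stands to compound 1: the change is chloro in place of hydrogen on an aromatic carbon, the same change at the same kind of place. Within the data shown here, the step from compound 2 to compound 4 is expected at a number 0.80 log units higher from compound 2 to compound 4 (beyond the scatter), beside the earlier one, because the step of a number 0.79 log units higher from compound 1 to compound 3 (beyond the scatter) is the only guide available for this change. For compound 4 the estimate is 8.7, expected between 8.2 and 9.2.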

Compound 4, partition coefficient: 8.7
Compound 4: middle estimate and measured number agree at the digits printed; the range from low to high includes it.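

In this assay chloro in place of hydrogen on an aromatic carbon gives a number 0.80 log units higher from compound 2 to compound 4 (beyond the scatter) and, on the core of compound 1, a number 0.79 log units higher from compound 1 to compound 3 (beyond the scatter). The two steps are nearly the same size, so in this series the change carries from one core to the other, and neither pair shown goes against this, although two pairs with the change at the same kind of place cannot establish a general rule or predict the step on a third core. Nothing measured here bears on why the two steps agree.

The compounds shown leave open whether the step stays the same size with chloro at another place on either core, or with an amine or a carboxylic acid entering in place of chloro. They also leave open whether it survives when a longer chain replaces the isobutyrate or benzoate esters.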